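Swapping Chloro for Methoxy on a Shared Core

This account rests on a few compounds, and the source may have more. Where it says the series, first, only, none or still open, it means among the compounds named here.

Of the compounds shown here, two built on one shared core have been tested in a functional assay on C6 cells (Rattus norvegicus) for cytotoxicity, read by MTT assay, with a stated time of 24 h, tested at 50 ug/mL; a lower number here means a stronger effect, a higher number a weaker effect of the compound at the concentration tested. Compound 1 `O=C(CSc1ncccn1)N/N=c1/scc(-c2ccc(Br)cc2)n1-c1ccccc1` gives 69%. Compound 2 `O=C(CSc1ncccn1)N/N=c1/scc(-c2ccc(Cl)cc2)n1-c1ccccc1` gives 61.8%, which places compound 2 at the bottom of the two numbers, with compound 1 its nearest neighbour; the step of a number 7.2 percentage points lower from compound 1 to compound 2 (within the scatter) is within the scatter. Compound 3 `COc1ccc(-c2cs/c(=N/NC(=O)CSc3ncccn3)n2-c2ccccc2)cc1` has not yet been measured. It differs from compound 2 at one place: methoxy in place of chloro on an aromatic carbon. For the measured compounds named here, the only measured step, a number 7.2 percentage points lower from compound 1 to compound 2 (within the scatter), exchanges one halogen for another and hardly moves the number, and no measured pair shows what a methoxy group does on this ring, so there is no basis for expecting a shift beyond the scatter in either direction in this assay. The expected step is a number 3.2 percentage points higher from compound 2 to compound 3 (within the scatter), a change within the scatter. Compound 3 is therefore estimated at 65%, with a range from 48% to 82%.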

Compound 3, a percentage reported as activity, at one concentration (the size of the read-out at that concentration, not a potency): 66.5%
Beside the measured number, compound 3's estimate is 1.5 percentage points below it; the measured number falls inside the stated range.
By their numbers in this assay, from the lowest: compounds 2, 3 and 1 (each within the scatter of the next).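

Compound 3 puts a group that is not a halogen at this place: in this assay methoxy gives a number 4.7 percentage points higher from compound 2 to compound 3 (within the scatter) when it replaces chloro and a number 2.5 percentage points lower from compound 1 to compound 3 (within the scatter) when it replaces bromo on the shared core. So a swap that brings in an oxygen and a hydrogen-bond acceptor still leaves all three compounds within the scatter of one another, as the exchange of one halogen for the other did. At this single test concentration, 4-chlorophenyl and 4-methoxyphenyl cannot be told apart. From the compounds shown here alone, whether an amine, a carboxylic acid or a longer chain at this place would give a number beyond the scatter remains open, as does the effect of changes elsewhere on the shared core. Nothing measured here gives a reason for the closeness of these numbers.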